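A Shorter Chain on Compound 2

The source may hold more compounds than are shown below. What is called first, only, known or untested is meant among the compounds shown, and "the series" means these compounds.

In a functional assay on PC-3 cells (Homo sapiens) for antiproliferative activity, with a stated time of 48 h (on this read-out lower numbers stand for stronger inhibition and higher numbers for weaker inhibition), three compounds have been measured. Compound 1 `COc1ccc(C(=O)/C=C/c2ccccc2)c(O)c1Br` gives 47800 nM. Compound 3 `COc1cc(O)c(C(=O)/C=C/c2ccccc2)cc1Br` gives only a limit of the assay, > 50000 nM, and not a number. Compound 2 `CCCOc1ccc(C(=O)/C=C/c2ccccc2)c(O)c1` gives 8080 nM, the lower of the two actual numbers, and its gap to compound 1 lies beyond the usual scatter of such measurements.

Compound 4 `CCOc1ccc(C(=O)/C=C/c2ccccc2)c(O)c1` departs from compound 2 by a single small edit: hydrogen in place of methyl on a saturated chain carbon, two bonds along the chain from an oxygen on an aromatic ring. Hydrogen stands in place of methyl on a saturated chain carbon, two bonds along the chain from an oxygen on an aromatic ring, so propoxy becomes ethoxy. Among the measured compounds shown here, no measured pair in this set isolates that change, so the expectation rests on its small size alone. In this assay, the step is expected to stay within the scatter or only slightly beyond it. A slight lean toward a higher number seems likely, with compound 2 at 8080 nM already holding the lowest number in hand. The expected change is a 1.2-fold higher number from compound 2 to compound 4 (0.09 log units; within the scatter). Compound 4 is estimated at about 10000 nM, with an expected range from 4000 nM to 27000 nM.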

Compound 4, half-maximal inhibitory concentration: 8200 nM
Beside the measured number, compound 4's estimate is 1.2-fold (0.09 log units) above it; measured number inside the range.
By their numbers in this assay, from the lowest: compounds 2 and 4 (each within the scatter of the next); then compound 1. At a limit, above all of these: compound 3.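

In this assay, among the compounds shown here, this is the first step in the set that isolates one place, and it gives a 1.0-fold higher number from compound 2 to compound 4 (0.01 log units; within the scatter). Where the earlier compounds could not separate any single edit, this pair shows that the methyl group on the saturated chain carbon, two bonds along the chain from an oxygen on an aromatic ring, can give way to hydrogen with no change that this read-out can resolve, so propoxy and ethoxy cannot be told apart here. The step is read between two actual numbers, and the only value that is a limit of the assay belongs to compound 3: the limit of > 50000 nM in this assay, at which 1 of the 4 values shown sits.

What the pair leaves open is whether this insensitivity extends further along the same chain, to a longer chain such as butoxy or to a chain ending in an amine or a carboxylic acid. Compound 1 and compound 3 differ from this pair in more than one place, so they do not say how the rest of the core bears on the numbers of compound 2 and compound 4.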